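Aryloxypropoxy thioether acids: a trifluoromethylphenyl variant

The source may hold more compounds than are shown below. What is called first, only, known or untested is meant among the compounds shown, and "the series" means these compounds.

Compound 1 `CCCCC(Sc1ccc(OCCCOc2ccccc2OC)cc1)C(=O)O` in an assay for inhibition of Polyunsaturated fatty acid 5-lipoxygenase (Homo sapiens), read by HPLC, with a stated time of 10 min (on this read-out lower numbers stand for stronger inhibition and higher numbers for weaker inhibition), gives only the assay limit, > 10000 nM, and no number. Compound 2 `Cc1cccc(OCCCOc2ccc(SCC(=O)O)cc2)c1C` in this assay likewise returns a limit, > 10000 nM. Within the data shown here, both measured values thus rest at the limit of > 10000 nM in this assay, at which 2 of the 2 values shown sit, so compound 1 has no definite standing on the scale and no measured step can be sized. Compound 3 `CCCCC(Sc1ccc(OCCCOc2cccc(C(F)(F)F)c2)cc1)C(=O)O` carries 3-(trifluoromethyl)phenyl in place of 2-methoxyphenyl on an oxygen on a saturated carbon. With two limits as the only reference, a shift toward stronger inhibition that clears the scatter is not expected; the change a step that the limit leaves unreadable from compound 1 to compound 3 is estimated to stay within it. Compound 3 is expected near 15000 nM, within 3000 nM to 60000 nM, most probably again as a limit.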

Compound 3, half-maximal inhibitory concentration: 9800 nM
Compound 3: the middle estimate sits 1.5-fold (0.18 log units) above what was measured; measured number inside the range.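

In this assay compound 3 gives 9800 nM, the only definite number among the compounds shown, so 3-(trifluoromethyl)phenyl on an oxygen on a saturated carbon returns a readable value. The change gives an at least 1.0-fold lower number from compound 1 to compound 3 (0.00 log units; that floor lies within the scatter), so no gain over 2-methoxyphenyl can be claimed. The other values remain limits: the limit of > 10000 nM in this assay, at which 2 of the 3 values shown sit.

On these data alone, the true size of this step stays open. Also open, as far as these compounds go, is how a nitrile or a chlorine in place of trifluoromethyl would read at this position.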